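Cytotoxicity notes on a lignan lactone triazole series

The compounds below may be only part of what the source reports. "The series", "measured", "known", "first", "only" and "open" are said of these compounds alone.

Measured compounds in an ADME assay on HeLa cells (Homo sapiens) for cytotoxicity, read by MTT assay; a lower number here means a stronger inhibitor, a higher number a weaker inhibitor:
- compound 1, `COc1ccc(C[C@H]2COC(=O)[C@@H]2Cc2ccc(OCc3cn(-c4cccc(Cl)c4)nn3)c(OC)c2)cc1OC`: 493000 nM
- compound 2, `COc1ccc(C[C@H]2COC(=O)[C@@H]2Cc2ccc(OCc3cn(Cc4ccccc4Cl)nn3)c(OC)c2)cc1OC`: 84500 nM
- compound 3, `COc1ccc(C[C@H]2COC(=O)[C@@H]2Cc2ccc(OCc3cn(Cc4ccccc4)nn3)c(OC)c2)cc1OC`: 346000 nM

Compound 3 stands second highest of the three numbers in this assay. Its nearest neighbour is compound 1, separated by a 1.4-fold lower number from compound 1 to compound 3 (0.15 log units; within the scatter), so the two cannot be told apart. Among the compounds with values here, the only step beyond the scatter that touches compound 3 is a 4.1-fold higher number from compound 2 to compound 3 (0.61 log units; beyond the scatter), where a chloro on the ring gave the lower number.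

Compound 4, `COc1ccc(C[C@H]2COC(=O)[C@@H]2Cc2ccc(OCc3cn(-c4ccc(Cl)cc4)nn3)c(OC)c2)cc1OC`, differs from compound 3 by 4-chlorophenyl in place of benzyl on an aromatic nitrogen. Within the data shown here, two measured steps bear on it. The swap of benzyl against a chlorophenyl on the ring nitrogen is covered by a 1.4-fold lower number from compound 1 to compound 3 (0.15 log units; within the scatter), which stayed within the scatter. Adding a chloro to the aromatic ring is covered by a 4.1-fold higher number from compound 2 to compound 3 (0.61 log units; beyond the scatter), a modest step, though there the chloro sat on a benzyl rather than a phenyl, and in a different position, so its transfer is uncertain. On balance no step beyond the scatter is expected for compound 4 in this assay, with a 1.0-fold higher number from compound 3 to compound 4 (0.00 log units; within the scatter) as the expected change, and compound 4 is estimated at 350000 nM, range 120000 nM to 1000000 nM.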

Compound 4, half-maximal inhibitory concentration: 279000 nM
Beside the measured number, compound 4's estimate is 1.3-fold (0.10 log units) above it; the range from low to high includes it.
By their numbers in this assay, from the lowest: compound 2; then compounds 4, 3 and 1 (each within the scatter of the next).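

In this assay, the triazole nitrogen tolerates a direct swap of benzyl for 4-chlorophenyl without a step that can be told from the scatter (a 1.2-fold lower number from compound 3 to compound 4 (0.09 log units; within the scatter)), and 4-chlorophenyl likewise cannot be told apart from 3-chlorophenyl (a 1.8-fold lower number from compound 1 to compound 4 (0.25 log units; within the scatter)). A chloro on the group at this nitrogen is therefore not enough on its own to reach the number of compound 2: 4-chlorophenyl still stands clear of 2-chlorobenzyl (a 3.3-fold higher number from compound 2 to compound 4 (0.52 log units; beyond the scatter)), and among these four compounds only the 2-chlorobenzyl group stands apart, with compounds 1, 3 and 4 forming one group that cannot be ordered. No measurement on hand accounts for the separation of compound 2.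

The compounds shown leave open whether that separation needs the chloro and the benzyl carbon together, since the only benzyl comparison is the chloro-free benzyl of compound 3 against the 2-chlorobenzyl of compound 2. They also leave open how this position responds to groups of another kind, such as a longer chain ending in a phenyl ring, an amine or a carboxylic acid.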